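Replacing 4-methoxybenzyl with 4-fluorobenzyl in compound 3

This account rests on a few compounds, and the source may have more. Where it says the series, first, only, none or still open, it means among the compounds named here.

Of the compounds shown here, two have been measured so far in an ADME assay on HEK-293T cells (Homo sapiens) for inhibition, read by CCK-8 assay, with a stated time of 48 h, tested at 20 uM; a lower number here means less inhibition of growth, a higher number more inhibition of growth at the concentration tested. Compound 1 `COc1ccc(Cc2nnc(NC(=O)/C(C#N)=C/c3ccccc3OS(=O)(=O)c3ccc(OC)cc3)s2)cc1` gives 30%, and compound 2 `COc1ccc(Cc2nnc(NC(=O)/C(C#N)=C/c3ccccc3OS(=O)(=O)c3ccc(Cl)cc3)s2)cc1` gives 34%. Going by the values given here, these two numbers lie within the scatter of each other, so compound 2 stands level with its only measured neighbour. Compound 3 `N#C/C(=C\c1ccccc1OS(=O)(=O)c1ccc(Cl)cc1)C(=O)Nc1nnc(Cc2ccc(F)cc2)s1` keeps the chloro group of compound 2 and alters the benzyl group: fluoro in place of methoxy on an aromatic carbon. This is fluoro in place of methoxy on an aromatic carbon, para to a large group, turning 4-methoxybenzyl into 4-fluorobenzyl. Among the compounds with values here, the one measured step that bears on this, a number 4 percentage points higher from compound 1 to compound 2 (within the scatter), also removed a methoxy group, though at another place in the molecule. No step beyond the scatter is therefore expected in this assay, though a single step is thin evidence. The expected change is a number 1 percentage points lower from compound 2 to compound 3 (within the scatter). For compound 3 the estimate is 33%, with an expected range from 20% to 47%.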

Compound 3, percent growth inhibition at one concentration: 6%
Compound 3: middle estimate off by 27 percentage points, on the high side, and the stated range ends above it.
By their numbers in this assay, from the lowest: compound 3; then compounds 1 and 2 (each within the scatter of the next).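

In this assay, the 4-methoxybenzyl position responds clearly to substitution: fluoro in place of methoxy, on an aromatic carbon para to a large group, gives a number 28 percentage points lower from compound 2 to compound 3 (beyond the scatter). The earlier change at another place in the molecule, chloro in place of methoxy, gave only a number 4 percentage points higher from compound 1 to compound 2 (within the scatter), so taking away a methoxy group does not have the same outcome everywhere, although the entering groups also differ between these two steps. No measurement shown here accounts for the drop.

The compounds shown leave open whether the lower number goes with the loss of methoxy or with the arrival of fluoro. A plain benzyl, 4-chlorobenzyl or 4-aminobenzyl group at this place would help separate the two, and the step rests on a single pair of compounds.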